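Nitro in Place of Hydrogen on an Inactive Pair

The compounds below may be only part of what the source reports. "The series", "measured", "known", "first", "only" and "open" are said of these compounds alone.

Compound 1 `O=c1ccoc2cc(OCc3cn(Cc4ccccc4)nn3)ccc12` was tested in a functional assay on HeLa cells (Homo sapiens) for cytotoxicity, read by MTT assay, with a stated time of 48 h; on this read-out higher numbers stand for weaker inhibition and lower numbers for stronger inhibition. In this assay compound 1 gives > 100000 nM, which is a limit of the assay rather than a number. Compound 2 `O=c1ccoc2cc(OCc3cn(Cc4ccccc4Cl)nn3)ccc12` carries chloro in place of hydrogen on an aromatic carbon. In this assay compound 2 gives > 100000 nM, again a limit. The step that the two limits leave unreadable from compound 1 to compound 2 cannot be read, since both values sit at the limit of > 100000 nM in this assay, at which 2 of the 2 values shown sit. Compound 3 `O=c1ccoc2cc(OCc3cn(Cc4ccc([N+](=O)[O-])cc4)nn3)ccc12` has not been measured; it differs from compound 1 by nitro in place of hydrogen on an aromatic carbon. Within the data shown here, the only measured step, from compound 1 to compound 2, was unreadable, so no size can be expected for this step in this assay, in either direction. Compound 1 stands at a limit alone. Compound 3 is therefore expected to give 150000 nM, within 50000 nM to 500000 nM, most probably once more as a limit. The step that the limit leaves unreadable from compound 1 to compound 3 is expected to be essentially none.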

Compound 3, half-maximal inhibitory concentration: 25700 nM
Estimate against measurement, compound 3: 5.8-fold (0.77 log units) above; measured number below the stated range.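

Nitro in place of hydrogen, on an aromatic carbon para to a large group, is the first change in this series that can be read in this assay, and it gives an at least 3.8-fold lower number from compound 1 to compound 3 (0.59 log units; beyond the scatter). Compound 3 also stands clear of the chloro compound, with 4-nitrophenyl in place of 2-chlorophenyl giving an at least 3.8-fold lower number from compound 2 to compound 3 (0.59 log units; beyond the scatter), so this ring can carry a change that brings a compound off the limit. Both steps give only a minimum size and their true size cannot be read, because compound 1 and compound 2 each stand at a limit: the limit of > 100000 nM in this assay, at which 2 of the 3 values shown sit.

As far as these compounds go, whether an amine or a carboxylic acid at the same place would also give a readable number stays open. From the compounds shown here alone, it is equally open whether nitro would do so at the place that chloro holds in compound 2.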